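The source may report more compounds than this note shows. Statements on the series, on what has been measured and on what is new or still open speak of the compounds shown alone.

Three compounds have been measured in a functional assay on A-375 cells (Homo sapiens) for antiproliferative activity, read by MTT assay, with a stated time of 48 h; on this read-out lower numbers stand for stronger inhibition and higher numbers for weaker inhibition:

Compound 1, `O=C(Nc1cc(-c2ccccc2)[nH]n1)c1ccc(Cl)nc1`, gives 7850 nM.
Compound 2, `COc1ccc(C(=O)Nc2cc(-c3ccccc3)[nH]n2)cn1`, gives 9560 nM.
Compound 3, `Cc1ccc(-c2cc(NC(=O)c3cccnc3Cl)n[nH]2)cc1`, gives 6440 nM.

Compound 1 and compound 2 differ in one place: methoxy in place of chloro on an aromatic carbon. That step gave a 1.2-fold higher number from compound 1 to compound 2 (0.09 log units; within the scatter), so the two numbers are indistinguishable within the usual repeat variation. Compound 3 carries a different core, and how its core differs from that of compound 1 is not broken down here; its value and that of compound 1 lie within the scatter of each other, as do its value and that of compound 2, so no order among the three is claimed.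

Compound 4, `COc1ncccc1C(=O)Nc1cc(-c2ccc(C)cc2)[nH]n1`, has not yet been measured. It is related to compound 3 by methoxy in place of chloro on an aromatic carbon. This is the same kind of change as that from compound 1 to compound 2, though not the same: in compound 2 the methoxy sits para to a large group, whereas in compound 4 it sits ortho to a large group.

Among the measured compounds shown here, on the strength of the only measured instance of this change, the step between compound 1 and compound 2 a 1.2-fold higher number from compound 1 to compound 2 (0.09 log units; within the scatter), the step from compound 3 to compound 4 is expected to be small, a 1.2-fold higher number from compound 3 to compound 4 (0.07 log units; within the scatter). For the measured compounds named here, compound 4 is therefore estimated to give 7500 nM in this assay, with a plausible range from 3500 nM to 16000 nM, the width reflecting the single precedent and the different position of the methoxy.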

Compound 4, half-maximal inhibitory concentration: 8730 nM
Compound 4: middle estimate off by 1.2-fold (0.07 log units), on the low side, within the range that was stated.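

In this assay, methoxy in place of chloro on an aromatic carbon of a six-membered aromatic ring with 1 nitrogen gave a 1.4-fold higher number from compound 3 to compound 4 (0.13 log units; within the scatter), so this step cannot be told apart from repeat variation. Set beside the earlier instance of the same change, it agrees with that step on the other core: the same change on two cores in this assay, a 1.2-fold higher number (0.09 log units; within the scatter) from compound 1 to compound 2 and a 1.4-fold higher number (0.13 log units; within the scatter) from compound 3 to compound 4, 1.1-fold (0.05 log units) apart, within the scatter of two such steps. This shows that, in these two pairs, swapping chloro for methoxy left the read-out indistinguishable on both cores, but it does not show that the swap is neutral in general, for two pairs are a small basis, and neither step is large enough to reveal any difference between the groups or any influence of the core or of where the group sits.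

The compounds shown carry only chloro or methoxy at this place, so what an amine, a hydroxyl, a carboxylic acid or a longer chain such as ethoxy would give on these cores remains open. Every step shown stays within the scatter, so it also remains open whether any replacement at this place can move the read-out measurably in this series.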